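A 3-Fluorophenyl in Place of a 4-Nitrophenyl

A few compounds are considered here, and "the series" means these few. Any claim that something is new, unique, unknown or untested is made for them only; others in the source may bear on it.

compound 1, `Cc1cnc(Nc2ccc([N+](=O)[O-])cc2)nc1Nc1nc2ccccc2s1`: 22500 nM in a functional assay on MDA-MB-231 cells (Homo sapiens) for antiproliferative activity, read by MTT assay, with a stated time of 48 h; a higher number here means a weaker inhibitor, a lower number a stronger inhibitor
compound 2, `CS(=O)(=O)c1ccc(Nc2nccc(Nc3nc4ccc(Cl)cc4s3)n2)cc1`: > 50000 nM in this assay, which is a limit of the assay and not a number

Compound 1 therefore holds the only number shown in this assay. The other entry, for compound 2, is a limit (the limit of > 50000 nM in this assay, at which 1 of the 2 values shown sits). For the measured compounds named here, no two measured compounds differ in a single place, so no measured step exists to guide the next one.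

Compound 3, `Cc1cnc(Nc2cccc(F)c2)nc1Nc1nc2ccccc2s1`, has not been measured. It differs from compound 1 by 3-fluorophenyl in place of 4-nitrophenyl on a nitrogen on an aromatic ring.

Without a measured step of this kind, the expected change from compound 1 to compound 3 is small, a 1.3-fold higher number from compound 1 to compound 3 (0.12 log units; within the scatter), most likely within the scatter and if anything toward a weaker inhibitor. Compound 3 is expected to give about 30000 nM in this assay, with a range from 8000 nM to 100000 nM.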

Compound 3, half-maximal inhibitory concentration: > 50000 nM
Compound 3 gave a limit, no number (the forecaster's own chance of this, stated with the estimate: 35%); at least 1.6-fold (0.22 log units) between middle value and limit.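

For the compounds shown here, the swap of 3-fluorophenyl in place of 4-nitrophenyl gives the first measured step on this nitrogen: in this assay, the change is an at least 2.2-fold higher number from compound 1 to compound 3 (0.34 log units; beyond the scatter). Compound 3 gives > 50000 nM, which is a limit of the assay and not a number, so this step has a known minimum size but no known full size. Compound 1 therefore remains the only compound with a number, and this change takes the series out of the measurable range: the limit of > 50000 nM in this assay, at which 2 of the 3 values shown sit.

The compounds shown leave open whether the weaker result follows from losing the nitro group, from adding the fluorine, or from the different ring position, as a 4-fluorophenyl or a 3-nitrophenyl group would help to separate these. As far as these compounds go, it also remains open whether a 4-aminophenyl or 4-carboxyphenyl group here would give a measurable value.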